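From 3-methylphenyl to 3,4-dimethoxyphenyl

A few compounds are considered here, and "the series" means these few. Any claim that something is new, unique, unknown or untested is made for them only; others in the source may bear on it.

Measured in a functional assay on HT-29 cells (Homo sapiens) for antiproliferative activity, read by MTT assay, with a stated time of 48 h; a higher number here means a weaker inhibitor of growth, a lower number a stronger inhibitor of growth:
Compound 1 `COC(=O)N1N=C(c2cccc(O)c2)CC1c1cc(OC)c(OC)c(OC)c1`: 1350 nM
Compound 2 `CCOc1cccc(C2=NN(C(=O)OC)C(c3cc(OC)c(OC)c(OC)c3)C2)c1`: 4450 nM
Compound 3 `COC(=O)N1N=C(c2cccc(C)c2)CC1c1cc(OC)c(OC)c(OC)c1`: 100 nM

Among these three, compound 3 has the lowest number at 100 nM, which makes it the strongest inhibitor of growth of the group. Compound 4 `COC(=O)N1N=C(c2ccc(OC)c(OC)c2)CC1c1cc(OC)c(OC)c(OC)c1` has not yet been measured. It carries 3,4-dimethoxyphenyl in place of 3-methylphenyl on a carbon with a double bond to nitrogen.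

The nearest evidence comes from the two compounds with an oxygen-linked group where compound 3 has its methyl. The first step is a 14-fold lower number from compound 1 to compound 3 (1.13 log units; beyond the scatter), and the second is a 45-fold lower number from compound 2 to compound 3 (1.65 log units; beyond the scatter). Read backwards, both show a large rise in the number when oxygen-linked groups stand in place of methyl. A further modest step, a 3.3-fold higher number from compound 1 to compound 2 (0.52 log units; beyond the scatter), separates the hydroxy and ethoxy compounds. For the measured compounds named here, no compound with methoxy or with two groups on this ring has been measured, so the size remains uncertain.

A large step is therefore expected, towards weaker inhibition, and the estimated change is a 15-fold higher number from compound 3 to compound 4 (1.18 log units; beyond the scatter). For compound 4 the estimate in this assay is 1500 nM, with an expected range from 350 nM to 6000 nM.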

Compound 4, concentration for 50% growth inhibition: 9200 nM
Compound 4: middle estimate off by 6.1-fold (0.79 log units), on the low side; measured number outside the range, above it.
By their numbers in this assay, from the lowest: compound 3; then compound 1; then compound 2; then compound 4.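

In this assay, 3,4-dimethoxyphenyl on the carbon with a double bond to nitrogen gives the weakest inhibitor of growth of the four compounds, and the change from 3-methylphenyl is the largest single step seen at this position: a 92-fold higher number from compound 3 to compound 4 (1.96 log units; beyond the scatter). The two-methoxy ring also stands beyond both rings with one oxygen-linked group, with a 2.1-fold higher number from compound 2 to compound 4 (0.32 log units; beyond the scatter) and a 6.8-fold higher number from compound 1 to compound 4 (0.83 log units; beyond the scatter), so the loss does not stop at the level of 3-ethoxyphenyl or 3-hydroxyphenyl, and all three oxygen-bearing compounds now lie on the weak side of the methyl compound, with none going against this among the four. No evidence is available that explains this loss of activity.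

The compounds shown leave open how much of the step belongs to each of the two methoxy groups, as a ring with one methoxy group alone is not among them. They also leave open whether an amine, a chlorine atom or a longer alkyl chain such as propyl, standing in place of the methyl, would keep the number near that of compound 3 at 100 nM.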